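The compounds below may be only part of what the source reports. "The series", "measured", "known", "first", "only" and "open" are said of these compounds alone.

Measured compounds in a physicochemical assay for lipophilicity; a lower number here means a more polar compound, a higher number a more lipophilic compound:
compound 1, `C[n+]1ccn(CCNS(=O)(=O)C(F)(F)F)c1/C=N/O`: compound 1 gives -1.2
compound 2, `CC(Cn1cc[n+](C)c1/C=N/O)NS(=O)(=O)C(F)(F)F`: compound 2 gives -0.82
compound 3, `C[n+]1ccn(CCCS(C)(=O)=O)c1/C=N/O`: compound 3 gives -2.7

Compound 1 and compound 2 differ in one place, (methyl in place of hydrogen on a saturated chain carbon bound to a saturated chain carbon and a sulfonamide nitrogen), and the step is a number 0.38 log units higher from compound 1 to compound 2 (beyond the scatter). Compound 3 stands lowest of the three, with gaps to compound 1 and compound 2 that lie beyond the scatter. The difference between the core of compound 3 and the core of compound 1 is not broken down here.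

Compound 4, `CC[n+]1ccn(CCCS(C)(=O)=O)c1/C=N/O`, is not yet measured in this assay. It differs from compound 3 by methyl in place of hydrogen on a saturated chain carbon bound to an aromatic nitrogen. This is the same kind of change as from compound 1 to compound 2, but the place is not the same: there the carbon is bound to a saturated chain carbon and a sulfonamide nitrogen, here to an aromatic nitrogen. Beside a number 0.38 log units higher from compound 1 to compound 2 (beyond the scatter), the expected step is a number 0.35 log units higher from compound 3 to compound 4 (beyond the scatter), resting on that single earlier step. Compound 4 is thus expected at -2.35, within -2.8 to -1.9.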

Compound 4, distribution coefficient: -2.6
Beside the measured number, compound 4's estimate is 0.25 log units above it, and the stated range covers the measured number.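

In this assay the methyl in place of hydrogen on a saturated chain carbon bound to an aromatic nitrogen gives a number 0.10 log units higher from compound 3 to compound 4 (within the scatter) and the same kind of change at the other place gave a number 0.38 log units higher from compound 1 to compound 2 (beyond the scatter) so the size of the earlier step did not carry over in this one pair. With only these two pairs, which differ in both core and place, the data do not show whether the core, the place or both set the size of the step. Nothing measured here accounts for the difference between the two steps.

Open, on these data alone, is whether a longer chain, such as propyl, or an amine on that same carbon would give a step beyond the scatter. Also open, as far as these compounds go, is how the methyl change would read at this place on the core of compound 1.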